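The source may hold more compounds than are shown below. What is called first, only, known or untested is meant among the compounds shown, and "the series" means these compounds.

Three compounds share one core: compound 1 `CCCN(CCC)c1ccc(NC(=O)c2cc(Cl)ccc2O)c(Cl)c1`, compound 2 `O=C(Nc1ccc(N2CCCC2)cc1Cl)c1cc(Cl)ccc1O` and compound 3 `O=C(Nc1ccc(NCC2CCCC2)cc1Cl)c1cc(Cl)ccc1O`. In an ADME assay on A549 cells (Homo sapiens) for cytotoxicity, read by LDH release, with a stated time of 15 h (a higher number here means that more compound is tolerated, a lower number that less compound is tolerated), compound 1 gives 323000 nM, compound 3 gives 141000 nM, and for compound 2 the result is "not determined" (no result reported). Compound 3 thus holds the lower of the two numbers, reached by a 2.3-fold lower number from compound 1 to compound 3 (0.36 log units; beyond the scatter). Compound 4 `CC(C)Nc1ccc(NC(=O)c2cc(Cl)ccc2O)c(Cl)c1` differs from compound 3 by isopropyl in place of cyclopentylmethyl on a nitrogen on an aromatic ring. Among the compounds with values here, no measured step exchanges one alkyl group for another on that nitrogen in this way, so the single step seen, a 2.3-fold lower number from compound 1 to compound 3 (0.36 log units; beyond the scatter), offers only a sense of scale: a modest shift. A shift of similar size in either direction, or none beyond the scatter, seems plausible. Compound 4 is expected to give 200000 nM, between 90000 nM and 450000 nM, which amounts to a 1.4-fold higher number from compound 3 to compound 4 (0.15 log units; within the scatter).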

Compound 4, half-maximal cytotoxic concentration: 82700 nM
Beside the measured number, compound 4's estimate is 2.4-fold (0.38 log units) above it, and the stated range ends above it.
By their numbers in this assay, from the lowest: compounds 4 and 3 (each within the scatter of the next); then compound 1.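

In this assay, isopropyl in place of cyclopentylmethyl on this nitrogen gives a 1.7-fold lower number from compound 3 to compound 4 (0.23 log units; within the scatter), so losing the ring makes no difference here that stands clear of the scatter. Isopropylamino in place of dipropylamino gives a 3.9-fold lower number from compound 1 to compound 4 (0.59 log units; beyond the scatter), and with the earlier step this places both compounds with a single alkyl group on this nitrogen, compound 3 and compound 4, at lower numbers than compound 1. No measurement shown explains these shifts. Still open, on these data alone, is whether a longer chain on this nitrogen, or one ending in a carboxylic acid, would stay in the same range.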